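Rearranging the Benzoic Acid End and Microsomal Stability

This account rests on a few compounds, and the source may have more. Where it says the series, first, only, none or still open, it means among the compounds named here.

Three compounds have been measured in an ADME assay (liver) for metabolic stability, with Liver microsome (Rattus norvegicus) as the target, read by LC-MS, using microsomes and NADPH, with stated times of 5 min and 60 min, tested at 4 uM; a higher number here means that more of the compound is left, a lower number that less of the compound is left:
Compound 1 `CCCC(=O)c1ccc(OCCCCOc2cc(C(=O)O)ccc2OC)c(C)c1O` gives 1%.
Compound 2 `Cc1cc(OCCCCOc2ccc(C(=O)CC3CCCC3)c(O)c2C)ccc1C(=O)O` gives 55%.
Compound 3 `Cc1c(OCCCCOc2ccc(C(=O)O)cc2F)ccc(C(=O)CC(C)C)c1O` gives 57%.

Compound 2 stands at the second highest of these three numbers. Its nearest neighbour is compound 3, whose value lies within the usual scatter of compound 2, so the two cannot be told apart. Compound 1 lies far below compound 2, a gap beyond the scatter, though compound 1 also differs from compound 2 in more than one part of the structure, so no single cause can be read from that pair.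

Compound 4 `Cc1ccc(C(=O)O)cc1OCCCCOc1ccc(C(=O)CC2CCCC2)c(O)c1C` has the same atoms as compound 2, joined differently: 5-carboxy-2-methylphenyl in place of 4-carboxy-3-methylphenyl on an oxygen on a saturated carbon. Among the measured compounds shown here, no measured pair shows this exact change on its own, so there is no direct guide to its size or direction in this assay. A modest loss is expected, with the possibility of no change beyond the scatter.

Compound 4 is estimated at 45%, between 20% and 70%. The expected step is a number 10 percentage points lower from compound 2 to compound 4 (within the scatter).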

Compound 4, percent of the compound remaining: 9%
The estimate for compound 4 lay 36 percentage points above the measured number, outside the stated range (below it).
By their numbers in this assay, from the lowest: compounds 1 and 4 (each within the scatter of the next); then compounds 2 and 3 (each within the scatter of the next).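

Rearranging the groups on this ring, with no atom gained or lost, is enough to change the outcome in this assay: 5-carboxy-2-methylphenyl in place of 4-carboxy-3-methylphenyl gives a number 46 percentage points lower from compound 2 to compound 4 (beyond the scatter). Among the compounds shown here, this is the first pair of compounds here that differ in one place, so it is the first direct sign that the arrangement of the benzoic acid end bears on how much compound remains. No measurement at hand gives a reason for this step.

Both the carboxy and the methyl numbers differ between the two groups, so the compounds shown do not separate the effect of one from the other. As far as these compounds go, it also remains open how the step would look with a chlorine atom in place of the methyl, or with a primary amide in place of the carboxylic acid.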